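This account rests on a few compounds, and the source may have more. Where it says the series, first, only, none or still open, it means among the compounds named here.

Working notes on the series, in an assay on HEK293 cells for displacement of a labelled ligand from 5-hydroxytryptamine receptor 7 (Rattus norvegicus), with a stated time of 60 min; a higher number here means a weaker inhibitor, a lower number a stronger inhibitor.

Among the measured compounds shown here, compound 2 `Clc1ccc(-c2cn(Cc3ccccc3)c3c2CNCC3)c(Cl)c1` gives 2070 nM in this assay, the lower of the two numbers measured so far. Compound 1 `FC(F)(F)Oc1ccc(-c2cn(Cc3ccccc3)c3c2CNCC3)cc1` gives 10000 nM in this assay, a higher number than that of compound 2 by a gap that lies beyond the usual scatter of the method. For the measured compounds named here, no step between these two has been worked out here; only their two values are to be read.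

The next compound, compound 3 `Cc1ccc(-c2cn(Cc3ccccc3)c3c2CNCC3)cc1`, differs from compound 2 by 4-methylphenyl in place of 2,4-dichlorophenyl on an aromatic carbon. The benzyl group and the shared core are left as they are. Going by the values given here, nothing in the measured pair tells how a 4-methylphenyl group at this carbon will behave; the only guide is that two different aryl groups at this place gave numbers a good way apart, so a change of some size is possible in either direction. The step from compound 2 to compound 3 is expected to be a 1.9-fold higher number from compound 2 to compound 3 (0.29 log units; within the scatter), a modest weakening rather than a gain, with wide uncertainty. Compound 3 is expected to give about 4000 nM in this assay, within a range from 1500 nM to 12000 nM.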

Compound 3, inhibition constant: 35 nM
Estimate against measurement, compound 3: 110-fold (2.06 log units) above; the whole stated range lies above it.
By their numbers in this assay, from the lowest: compound 3; then compound 2; then compound 1.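

In this assay, the aryl group on this aromatic carbon of the five-membered ring governs the number over a much wider span than the first two compounds showed: 4-methylphenyl in place of 2,4-dichlorophenyl gives a 59-fold lower number from compound 2 to compound 3 (1.77 log units; beyond the scatter), and methyl in place of trifluoromethoxy on the aryl group gives a 290-fold lower number from compound 1 to compound 3 (2.46 log units; beyond the scatter). Among the compounds shown here, both steps lie beyond the scatter, so with the benzyl group and the shared core unchanged, this one place is enough to take the series from the weak numbers of the first two compounds to compound 3 at 35 nM. Nothing measured here accounts for the size of these steps.

The step from compound 2 to compound 3 removes two chlorine atoms and adds a methyl at once, so the compounds shown cannot separate these changes, and the place of an unsubstituted phenyl, a 4-chlorophenyl or a 4-ethylphenyl group on this carbon remains open. As far as these compounds go, how far compound 3 would hold its number with a longer alkyl chain or a pyridine ring in place of the benzyl group also stays open.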